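A few compounds are considered here, and "the series" means these few. Any claim that something is new, unique, unknown or untested is made for them only; others in the source may bear on it.

Measured compounds:
- Compound 1, `CC1=C(N2CC2)C(=O)C(Cc2ccccc2)=C(N2CC2)C1=O`, gives 4.69 in a functional assay on L1210 cells (Mus musculus), with a stated time of 12 days; on this read-out lower numbers stand for lower potency and higher numbers for higher potency (the scale is a negative logarithm).
- Compound 2, `CC1=C(N2CC2)C(=O)C(C(C)C)=C(N2CC2)C1=O`, gives 5.21 in this assay.
- Compound 3, `CCOC(COC(N)=O)C1=C(N2CC2)C(=O)C(CC)=C(N2CC2)C1=O`, gives 5.24 in this assay.

Among these three, compound 1 stands lowest: compound 2 lies beyond the scatter above it, and compound 3 lies a little further above it still. For the measured compounds named here, the one measured step that changes a single place is a number 0.52 log units higher from compound 1 to compound 2 (beyond the scatter), a modest rise. Compound 3 differs from compound 1 in more than one place, so its value shows only that a different pairing of groups on the shared core also reaches a higher number.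

The unmeasured compound 4, `CC1=C(N2CC2)C(=O)C(COc2ccccc2)=C(N2CC2)C1=O`, differs from compound 1 as follows: phenoxy in place of phenyl on a saturated chain carbon bound to a double-bonded ring carbon. Going by the values given here, no measured pair shows this kind of change, where an oxygen is inserted and the aromatic ring kept; the step from compound 1 to compound 2 swaps the ring for a small branched chain instead, and thus bears on it only loosely. The expectation is therefore a small step at most, likely within the scatter, with a slight lean upward because a number 0.52 log units higher from compound 1 to compound 2 (beyond the scatter) shows that moving away from the benzyl of compound 1 did not lower the number. Compound 4 is estimated at 4.9, in the range 4.4 to 5.5, an expected step of a number 0.21 log units higher from compound 1 to compound 4 (within the scatter).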

Compound 4, logarithm of the reciprocal of the active concentration, log(1/C): 4.71
For compound 4 the middle estimate is 0.19 log units above the measured one, and the stated range covers the measured number.
By their numbers in this assay, from the lowest: compounds 1 and 4 (each within the scatter of the next); then compounds 2 and 3 (each within the scatter of the next).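

In this assay, the added oxygen in the side chain, with the aromatic ring kept, gives a number 0.02 log units higher from compound 1 to compound 4 (within the scatter), so compound 1 and compound 4 cannot be told apart on this read-out. For the compounds shown here, the earlier single-place step, a number 0.52 log units higher from compound 1 to compound 2 (beyond the scatter), replaced the aromatic ring with a small branched chain, and only that step lies beyond the scatter; at this position, then, phenoxy in place of phenyl is a swap that the number does not register. No measurement presented here offers an explanation for this result.

Going by these compounds, whether an amine or a carboxylic acid on the same chain would shift the number remains open. So does whether a longer chain, such as hexyl, or a tert-butyl group would match the number of compound 2.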